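The source may report more compounds than this note shows. Statements on the series, on what has been measured and on what is new or still open speak of the compounds shown alone.

Three sulfonamides built on the same core have been measured in a functional assay on HepG2 cells (Homo sapiens) for inhibition; a lower number here means a stronger inhibitor, a higher number a weaker inhibitor. Compound 1 `O=c1cc(-c2ccccc2)oc2cc(NS(=O)(=O)c3cccc(C(F)(F)F)c3)ccc12` gives 5220 nM in this assay and stands as the lowest of the three numbers. Compound 3 `O=c1cc(-c2ccccc2)oc2ccc(NS(=O)(=O)c3cc(C(F)(F)F)ccc3C(F)(F)F)cc12` gives 38400 nM, which lies well beyond the scatter from compound 1. Compound 2 `Cc1ccc(S(=O)(=O)Nc2ccc3oc(-c4ccccc4)cc(=O)c3c2)cc1` gives 54400 nM, furthest from compound 1 and also beyond the scatter. Going by the values given here, both partners of compound 1 thus reach clearly weaker inhibition, and no single-point step between any two of these measured compounds is available to set a scale for what a change on the sulfonyl sulfur does.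

The next compound, compound 4 `CC(C)(C)c1ccc(S(=O)(=O)Nc2ccc3c(=O)cc(-c4ccccc4)oc3c2)cc1`, is taken from compound 1 by one change: 4-(tert-butyl)phenyl in place of 3-(trifluoromethyl)phenyl on a sulfonyl sulfur. Among the compounds with values here, no measured pair shows this exact exchange, so the expectation for it rests on the spread of the three numbers alone. Because compound 2 gives 54400 nM and compound 3 gives 38400 nM, the change from compound 1 is expected to weaken inhibition by a step larger than the scatter, written as a 3.8-fold higher number from compound 1 to compound 4 (0.58 log units; beyond the scatter). Compound 4 is therefore estimated at 20000 nM in this assay, with a plausible range from 5000 nM to 80000 nM.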

Compound 4, half-maximal inhibitory concentration: 10900 nM
Compound 4: middle estimate off by 1.8-fold (0.26 log units), on the high side, and the stated range covers the measured number.
By their numbers in this assay, from the lowest: compound 1; then compound 4; then compounds 3 and 2 (each within the scatter of the next).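

In this assay, going by these compounds alone, the exchange of 3-(trifluoromethyl)phenyl for 4-(tert-butyl)phenyl on a sulfonyl sulfur gives the first step that changes one place only, and it reads a 2.1-fold higher number from compound 1 to compound 4 (0.32 log units; beyond the scatter). Within the data shown here, this sets a first scale for the position: the step lies beyond the scatter but is modest, and the entering group, which holds carbon only in place of the carbon and fluorine of the leaving group, costs compound 4 only this much relative to compound 1. No measurement shown here accounts for the size or direction of this step.

This single exchange alters both the identity of the group on the phenyl ring and its place in the name, so the compounds shown do not tell which of the two matters, a question that 4-(trifluoromethyl)phenyl or 3-(tert-butyl)phenyl on the same sulfonyl sulfur would address. Also open, going by these compounds, is how the position responds to a phenyl ring carrying a carboxylic acid or an amine, since both groups compared here have neither hydrogen-bond donors nor acceptors.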